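This account rests on a few compounds, and the source may have more. Where it says the series, first, only, none or still open, it means among the compounds named here.

Compound 2 `O=C(NC(=S)N1CCc2c(OCCCCCOc3ccc(Cl)cc3)cccc21)C1CCCCC1` stands at the upper end of the numbers seen so far: in an ADME assay on Huh-7 cells (Homo sapiens) for cytotoxicity (on this read-out lower numbers stand for higher toxicity in this test and higher numbers for lower toxicity in this test), compound 2 gives > 50000 nM, which is a limit of the assay and not a number. Compound 1 `O=C(NC(=S)N1CCc2c(OCCCCCOc3ccc(Cl)cc3)cccc21)c1ccc(Cl)cc1` gives 21700 nM in this assay. Going by the values given here, the only measured step, an at least 2.3-fold higher number from compound 1 to compound 2 (0.36 log units; beyond the scatter), bears on the new change and rests on (the limit of > 50000 nM in this assay, at which 1 of the 2 values shown sits). Compound 3 `O=C(NC(=S)N1CCc2c(OCCCCCOc3ccc(Cl)cc3)cccc21)c1cc2ccccc2s1` carries 1-benzothiophen-2-yl in place of cyclohexyl on a carbonyl carbon, so an aromatic group again replaces cyclohexyl, the reverse sense of the measured step. For compound 3 the number is therefore expected to fall, an at least 2.2-fold lower number from compound 2 to compound 3 (0.35 log units; beyond the scatter), to an estimated 22000 nM in this assay, within 8000 nM to 50000 nM.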

Compound 3, half-maximal cytotoxic concentration: > 50000 nM
Compound 3: no number, only a limit; the forecaster's own chance of this, stated with the estimate: 35%; middle value at least 2.2-fold (0.35 log units) from the limit.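

In this assay compound 3 gives > 50000 nM, which is a limit of the assay and not a number. 1-Benzothiophen-2-yl in place of 4-chlorophenyl gives an at least 2.3-fold higher number from compound 1 to compound 3 (0.36 log units; beyond the scatter), so an aromatic group on this carbonyl carbon does not by itself bring the lower number seen with compound 1. The step between compound 2 and compound 3 cannot be read, because both sit at the same limit: the limit of > 50000 nM in this assay, at which 2 of the 3 values shown sit.

Going by these compounds, how far compound 2 and compound 3 lie past that limit stays open. Also open, on these data alone, is whether the lower number of compound 1 goes with its chlorine, which a plain phenyl on this carbonyl carbon would test.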